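This account rests on a few compounds, and the source may have more. Where it says the series, first, only, none or still open, it means among the compounds named here.

Compound 1 `CC(C)CNc1ccc(NC(=O)c2cc(Cl)ccc2O)c(Cl)c1` stands second highest of the three compounds measured in an ADME assay on A549 cells (Homo sapiens) for cytotoxicity, read by resazurin assay, with a stated time of 48 h (a higher number here means that more compound is tolerated, a lower number that less compound is tolerated), where compound 1 gives 60000 nM. Its nearest neighbour is compound 3 `CN(C)c1ccc(NC(=O)c2cc(Cl)ccc2O)c(Cl)c1`, for which compound 3 gives 85100 nM; furthest is compound 2 `CCCCCCC(C)Nc1ccc(NC(=O)c2cc(Cl)ccc2O)c(Cl)c1`, for which compound 2 gives 23500 nM. Among the measured steps, a 2.6-fold lower number from compound 1 to compound 2 (0.41 log units; beyond the scatter) and a 3.6-fold higher number from compound 2 to compound 3 (0.56 log units; beyond the scatter) bear on the change to compound 4 `CC(C)(C)OC(=O)NCCNc1ccc(NC(=O)c2cc(Cl)ccc2O)c(Cl)c1`, which is ((tert-butoxycarbonyl)amino)methyl in place of isopropyl on a saturated chain carbon bound to a nitrogen on an aromatic ring. Both of those steps show that lengthening the chain on the nitrogen gave a lower number and shortening it a higher one, while a 1.4-fold higher number from compound 1 to compound 3 (0.15 log units; within the scatter) stayed within the scatter. Within the data shown here, compound 4 carries a longer chain than compound 1, but one with a donor and two acceptors rather than further carbons, so no measured pair matches it closely. Compound 4 is therefore expected to give a number somewhat lower than compound 1, at 45000 nM, with a range from 20000 nM to 95000 nM. The expected step is a 1.3-fold lower number from compound 1 to compound 4 (0.12 log units; within the scatter).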

Compound 4, half-maximal cytotoxic concentration: 25000 nM
The estimate for compound 4 lay 1.8-fold (0.26 log units) above the measured number, and the stated range covers the measured number.
By their numbers in this assay, from the lowest: compounds 2 and 4 (each within the scatter of the next); then compounds 1 and 3 (each within the scatter of the next).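

In this assay, a 2.4-fold lower number from compound 1 to compound 4 (0.38 log units; beyond the scatter) shows that the number at this position can fall with a group that is not purely carbon, since ((tert-butoxycarbonyl)amino)methyl brings in nitrogen, oxygen, a hydrogen-bond donor and hydrogen-bond acceptors. Compound 2 gives 23500 nM and compound 4 gives 25000 nM, values within the scatter of each other, so 1-methylheptyl and this carbamate-bearing chain reach the same level despite their different atoms. Nothing measured here accounts for the change.

The compounds shown leave open whether the tert-butoxycarbonyl group or the added chain length matters more for this step. They also leave open where the number would lie with a free primary amine, a hydroxyl or a carboxylic acid at the end of the chain.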